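This account rests on a few compounds, and the source may have more. Where it says the series, first, only, none or still open, it means among the compounds named here.

Compound 1 `CC(=O)OCCOCn1cnc2c(Cl)ncnc21`: 475 ug/mL
Compound 2 `CC(=O)OCCOCn1cnc2c(Cl)nc(Cl)nc21`: 412 ug/mL

In a functional assay on L1210 cells (Mus musculus) for inhibition (a lower number here means a stronger inhibitor, a higher number a weaker inhibitor), compound 2 stands at 412 ug/mL, with compound 1 within the scatter of it at 475 ug/mL. Compound 3 `CC(=O)OCCOCn1cnc2c(Cl)nc(N)nc21` has not yet been measured; it differs from compound 2 by amino in place of chloro on an aromatic carbon. Among the compounds with values here, the only measured step, a 1.2-fold lower number from compound 1 to compound 2 (0.06 log units; within the scatter), concerns chloro in place of hydrogen on an aromatic carbon, a different change, and it sits within the scatter, so it bears on the new step only loosely. Within the data shown here, no measured pair shows chloro exchanged for amino. The step from compound 2 to compound 3 is therefore expected to stay within the scatter, a 1.0-fold lower number from compound 2 to compound 3 (0.01 log units; within the scatter). Compound 3 is estimated at 400 ug/mL, with a range from 150 ug/mL to 1000 ug/mL.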

Compound 3, concentration for 50% inhibition: > 1000 ug/mL
Compound 3 was reported as a limit; the forecaster's own chance of this, stated with the estimate: 15%; at least 2.5-fold (0.39 log units) between middle value and limit.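

In this assay, the aromatic carbon between two ring nitrogen atoms turns out to respond to substitution, which chloro in place of hydrogen had not shown: amino in place of chloro gives an at least 2.4-fold higher number from compound 2 to compound 3 (0.38 log units; beyond the scatter), and amino in place of hydrogen gives an at least 2.1-fold higher number from compound 1 to compound 3 (0.32 log units; beyond the scatter). Compound 3 sits at a limit of the assay, > 1000 ug/mL. Both steps are therefore open-ended: the limit of > 1000 ug/mL in this assay, at which 1 of the 3 values shown sits.

As far as these compounds go, how far compound 3 truly lies from the other two stays open. So does whether a methylamino, methoxy or hydroxyl group at this position would behave like amino.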